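The compounds below may be only part of what the source reports. "The series", "measured", "known", "first", "only" and "open" are said of these compounds alone.

Among the compounds with values here, compound 3 `COc1ccc(N2C[C@@H](C)N[C@@H](C)C2)cc1NS(=O)(=O)c1ccc(-c2cccs2)cc1` gives 1 in a functional assay for agonist activity at growth hormone secretagogue receptor type 1 (Homo sapiens), read by FLIPR (on this read-out lower numbers stand for smaller maximal responses and higher numbers for larger maximal responses), and stands second highest of the three measured members. Compound 1 `COc1ccc(F)c(-c2ccc(S(=O)(=O)Nc3cc(N4C[C@@H](C)N[C@@H](C)C4)ccc3OC)cc2)c1` gives 1.2 in this assay, and the step is a number 0.20 lower from compound 1 to compound 3 (beyond the scatter). Compound 2 `COc1ccc(N2C[C@@H](C)N[C@@H](C)C2)cc1NS(=O)(=O)c1ccc(-c2cncnc2)cc1` gives 0.6 in this assay, and the step is a number 0.40 higher from compound 2 to compound 3 (beyond the scatter); between the two outer members the step is a number 0.60 lower from compound 1 to compound 2 (beyond the scatter).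

Compound 4 `COc1ccc(N2C[C@@H](C)N[C@@H](C)C2)cc1NS(=O)(=O)c1ccc(-c2cccs2)cc1Cl` differs from compound 3 by chloro in place of hydrogen on an aromatic carbon. Within the data shown here, all three measured steps exchange the group on the aromatic carbon that carries the aryl ring; none adds a chloro, so no measured step bears directly on this change, and in this assay no step beyond the scatter is expected. Compound 4 is estimated at 1, with a range of 0.7 to 1.2, that is an expected step of no change at the digits printed from compound 3 to compound 4 (within the scatter).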

Compound 4, intrinsic activity: the largest response reached, as a fraction of the reference agonist's: 0.9
Compound 4: middle estimate off by 0.10, on the high side, and the stated range covers the measured number.
By their numbers in this assay, from the lowest: compound 2; then compounds 4 and 3 (each within the scatter of the next); then compound 1.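

In this assay chloro in place of hydrogen gives a number 0.10 lower from compound 3 to compound 4 (within the scatter) and so this carbon, ortho to a large group and meta to a thiophen-2-yl group, accepts a chlorine without a step beyond the scatter. Within the data shown here, the earlier steps exchanged only the aryl group, so this is the first reading from another place on that ring. The data give no measured reason for this result.

On these data alone, whether an amine or a carboxylic acid at this carbon would also stay within the scatter remains open. Also open, as far as these compounds go, is whether chloro gives the same result with pyrimidin-5-yl or 2-fluoro-5-methoxyphenyl in place of thiophen-2-yl.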